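A few compounds are considered here, and "the series" means these few. Any claim that something is new, unique, unknown or untested is made for them only; others in the source may bear on it.

Measured compounds:
- compound 1 `CSc1nc(Cl)c2ccn(COCCO)c2n1`: > 100000 nM
- compound 2 `CC(=O)OCCOCn1ccc2c(Cl)nc(Cl)nc21`: > 100000 nM

In a functional assay on BSC-1 cells (Cercopithecidae) for cytotoxicity (on this read-out lower numbers stand for stronger inhibition and higher numbers for weaker inhibition), compound 1 returns only a limit of the assay, > 100000 nM. In this assay compound 2 likewise returns only a limit, > 100000 nM. Among the measured compounds shown here, compound 2 therefore stands at the limit of > 100000 nM in this assay, at which 2 of the 2 values shown sit, and no number separates it from compound 1; no step between measured compounds can be drawn from these two values. Compound 3 `OCCOCn1ccc2c(Cl)nc(Cl)nc21` is not yet measured in this assay. It differs from compound 2 by hydrogen in place of acetyl on an oxygen on a saturated carbon. For the measured compounds named here, no measured pair shows the effect of this change, so no direction beyond the scatter is assumed for the step from compound 2 to compound 3 in this assay, and the expectation is that compound 3 also returns a limit rather than a number. The estimate for compound 3 in this assay is 150000 nM, within the range 50000 nM to 500000 nM. This corresponds to an expected step that the limit leaves unreadable from compound 2 to compound 3.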

Compound 3, half-maximal inhibitory concentration: > 100000 nM
Compound 3: no number, only a limit; the forecaster's own chance of this, stated with the estimate: 85%; the middle value does not contradict the limit.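

Compound 3 in this assay returns only a limit, > 100000 nM. Among the compounds shown here, no step from compound 1 or compound 2 to compound 3 can be read from these limits. The compounds shown leave open whether hydrogen in place of acetyl, or chloro in place of methylsulfanyl, shifts the read-out in this assay at all.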